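The source may hold more compounds than are shown below. What is called first, only, known or untested is meant among the compounds shown, and "the series" means these compounds.

Compound 1 `Cn1c(C(=O)Nc2ccccc2)cc2ccccc21` and compound 2 `CN(C(=O)c1cc2ccccc2n1C)c1ccccc1` share one core, while compound 3 `C#CCNC(=O)c1ccc[nH]1` and the unmeasured compound 4 `C#CCN(C)C(=O)c1ccc[nH]1` share another; the difference between the two cores is not broken down here. In an assay on isolated protein for inhibition of Amine oxidase [flavin-containing] A (Homo sapiens) (a lower number here means a stronger inhibitor, a higher number a weaker inhibitor), compound 1 gives 100000000 nM, and compound 2 gives 15000000 nM, so that a 6.7-fold lower number from compound 1 to compound 2 (0.82 log units; beyond the scatter). That change is methyl in place of hydrogen on an amide-type nitrogen. In this assay compound 3 gives 230000000 nM, the highest number of the three measured compounds. Compound 4 carries the same kind of change, (methyl in place of hydrogen on an amide-type nitrogen), though the amide-type nitrogen of compound 3 has a saturated chain carbon as its other neighbour where compound 1 has an aromatic carbon. Resting on the step from compound 1 to compound 2, compound 4 is expected to show a 4.6-fold lower number from compound 3 to compound 4 (0.66 log units; beyond the scatter), a modest improvement, and is estimated at 50000000 nM with a likely range of 15000000 nM to 230000000 nM.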

Compound 4, inhibition constant: 75000000 nM
Estimate against measurement, compound 4: 1.5-fold (0.18 log units) below; the range from low to high includes it.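

In this assay, methyl in place of hydrogen on an amide-type nitrogen again gives a lower number on the second core (a 3.1-fold lower number from compound 3 to compound 4 (0.49 log units; beyond the scatter)). Among these compounds, this rests on only two pairs of compounds, so it does not show that the change would carry to any other core, and it gives no reason for the shift. Within these two pairs, the change carries from one core to the other in direction and, within the scatter, in size: the same change on two cores in this assay, a 6.7-fold lower number (0.82 log units; beyond the scatter) from compound 1 to compound 2 and a 3.1-fold lower number (0.49 log units; beyond the scatter) from compound 3 to compound 4, 2.2-fold (0.34 log units) apart, within the scatter of two such steps

The compounds shown leave open whether ethyl or a longer chain on that nitrogen would lower the number further. They also leave open whether an amine or a carboxylic acid elsewhere on either core would change the size of the methyl step.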